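Biphenyl amide boronates: sulfamoyl carbamate replacing trifluoromethyl

The compounds below may be only part of what the source reports. "The series", "measured", "known", "first", "only" and "open" are said of these compounds alone.

Measured so far in an assay on isolated protein for inhibition of serine protease 1 (Homo sapiens); a higher number here means a weaker inhibitor, a lower number a stronger inhibitor:
compound 1 `Cc1cc(-c2ccccc2)ccc1C(=O)N[C@@H](CCCN=C(N)N)B1O[C@@H]2CC3CC(C3(C)C)[C@]2(C)O1`: 4.2 nM
compound 2 `CC(C)(C)OC(=O)Nc1cccc(-c2ccc(C(=O)N[C@@H](CCCN=C(N)N)B3O[C@@H]4CC5CC(C5(C)C)[C@]4(C)O3)o2)c1`: 25 nM
compound 3 `Cc1cc(-c2ccccc2C(F)(F)F)ccc1C(=O)N[C@@H](CCCN=C(N)N)B1O[C@@H]2CC3CC(C3(C)C)[C@]2(C)O1`: 3.1 nM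

Compound 3 gives the lowest number of the three, but its gap to compound 1 is within the scatter; only compound 2 sits clearly higher. Compound 4 `COC(=O)NS(=O)(=O)c1ccccc1-c1ccc(C(=O)N[C@@H](CCCN=C(N)N)B2O[C@@H]3CC4CC(C4(C)C)[C@]3(C)O2)c(C)c1` is the next step from compound 3: (methoxycarbonyl)sulfamoyl in place of trifluoromethyl on an aromatic carbon. Within the data shown here, no measured step covers this exchange. Among the measured compounds shown here, the one step at the same aromatic carbon, a 1.4-fold lower number from compound 1 to compound 3 (0.13 log units; within the scatter), shows that the trifluoromethyl itself changed little. The new group is larger and carries a donor and several acceptors, yet nothing measured here speaks to it. The expectation for compound 4 in this assay is therefore a step of a 1.1-fold higher number from compound 3 to compound 4 (0.05 log units; within the scatter), not beyond the scatter, with a wide range: compound 4 is estimated at 3.5 nM (range 1.2 nM to 12 nM).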

Compound 4, inhibition constant: 0.64 nM
Beside the measured number, compound 4's estimate is 5.5-fold (0.74 log units) above it; the measured number lies below the stated range.
By their numbers in this assay, from the lowest: compound 4; then compounds 3 and 1 (each within the scatter of the next); then compound 2.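

In this assay the step of a 1.4-fold lower number from compound 1 to compound 3 (0.13 log units; within the scatter) had left this aromatic carbon looking unresponsive, whereas the step of a 4.8-fold lower number from compound 3 to compound 4 (0.69 log units; beyond the scatter) shows that the substituent there can move the number. The step of a 6.6-fold lower number from compound 1 to compound 4 (0.82 log units; beyond the scatter) gives the same reading against hydrogen, so a group of this size, with a donor and acceptors, is accepted at this place. No evidence is at hand on why the number falls.

Which part of the (methoxycarbonyl)sulfamoyl group carries the step stays open. A plain sulfonamide or a carboxylic acid on the same aromatic carbon would help separate the sulfamoyl part from the methoxycarbonyl part.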